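A methyl added to compound 1, meta to a large group

This account rests on a few compounds, and the source may have more. Where it says the series, first, only, none or still open, it means among the compounds named here.

Compound 1 `CS(=O)(=O)c1ccc(-c2cnc3[nH]cc(-c4nnc(-c5ccccc5)o4)c(=O)c3c2)cc1`: 9.51%
Compound 2 `N#Cc1ccc(-c2cnc3[nH]cc(-c4nnc(-c5ccc(Cl)cc5)o4)c(=O)c3c2)cc1`: 12.5%
Compound 3 `O=c1c(-c2nnc(-c3ccc(Cl)cc3)o2)c[nH]c2ncc(-c3ccccc3)cc12`: 9.77%

In a functional assay on A549 cells (Homo sapiens) for inhibition, read by MTT assay, with a stated time of 24 h, tested at 10 uM (a higher number here means more inhibition of growth at the concentration tested, a lower number less inhibition of growth), compound 1 gives 9.51%, and its number sits no further than the usual scatter from compound 3, its nearest neighbour, and from compound 2, the furthest of the three. Going by the values given here, the one measured step that changes a single place, a number 2.7 percentage points lower from compound 2 to compound 3 (within the scatter), also stays within the scatter, so nothing in this small set moves the read-out.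

Compound 4 `Cc1cccc(-c2nnc(-c3c[nH]c4ncc(-c5ccc(S(C)(=O)=O)cc5)cc4c3=O)o2)c1` differs from compound 1 by methyl in place of hydrogen on an aromatic carbon. Among the compounds with values here, no measured step touches this change: the only step available concerns a nitrile on another ring and did nothing beyond the scatter. Within the data shown here, with all three measured numbers clustered together and no step showing movement, compound 4 is expected to stay near compound 1, the expected change being a number 0.5 percentage points higher from compound 1 to compound 4 (within the scatter). Compound 4 is therefore estimated at 10%, with an expected range from 0% to 25%.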

Compound 4, percent growth inhibition at one concentration: 8.95%
Compound 4: middle estimate off by 1.1 percentage points, on the high side; the range from low to high includes it.
By their numbers in this assay, from the lowest: compounds 4, 1, 3 and 2 (each within the scatter of the next).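

In this assay, the change from phenyl to 3-methylphenyl, a methyl on an aromatic carbon meta to a large group, reads as a number 0.6 percentage points lower from compound 1 to compound 4 (within the scatter). Going by these compounds alone, this is the first reading of a change on this ring: the earlier step concerned a nitrile on another ring, so it could say nothing about this position, which now takes a methyl without a shift beyond the scatter. Nothing available here accounts for this result.

One methyl at one place leaves open what a different group would do there, such as a methoxy, an amine or a carboxylic acid, and what a methyl would do elsewhere on the same ring. The compounds shown also leave open whether any change on this ring can carry the number in this assay beyond the scatter.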